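The source may hold more compounds than are shown below. What is called first, only, known or untested is meant among the compounds shown, and "the series" means these compounds.

Compound 1, `CCOCCOc1cccc2ccc(N)nc12`, compound 2, `Nc1ccc2cccc(OC3CCCC3)c2n1`, and compound 3, `CCC(CC)C(C)Oc1cccc2ccc(N)nc12`, were measured in an assay on cells with melanin-concentrating hormone receptor 1 (Homo sapiens) as the target, read by radioligand binding; on this read-out lower numbers stand for stronger inhibition and higher numbers for weaker inhibition.

In this assay compound 1 reaches only a limit of the assay, > 2000 nM. Compound 2 likewise reaches only a limit, > 2000 nM. For the measured compounds named here, compound 3 gives 191 nM, the only real number among the three; the other two sit at the limit of > 2000 nM in this assay, at which 2 of the 3 values shown sit. Going by the values given here, the one measured step, a step that the two limits leave unreadable from compound 1 to compound 2, joins two limits and so tells nothing usable about size or direction.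

Compound 4, `CCOCC(C)Oc1cccc2ccc(N)nc12`, has not yet been measured. It differs from compound 3 by ethoxymethyl in place of pentan-3-yl on a saturated chain carbon bound to an oxygen on an aromatic ring and a saturated chain carbon. Among the compounds with values here, no measured step bears directly on this change. What can be said is that compound 1, which also carries an ether oxygen in its chain on the oxygen on the aromatic ring, reaches only a limit, while compound 3, whose chain is all carbon, gives a number. On that basis compound 4 is expected to lose potency, with an estimated step of a 7.9-fold higher number from compound 3 to compound 4 (0.90 log units; beyond the scatter), and it may well fall back to the limit. The estimate for compound 4 in this assay is 1500 nM, with a range from 400 nM to 6000 nM.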

Compound 4, half-maximal inhibitory concentration: 1070 nM
For compound 4 the middle estimate is 1.4-fold (0.15 log units) above the measured one, and the stated range covers the measured number.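

In this assay, the change from pentan-3-yl to ethoxymethyl gives a 5.6-fold higher number from compound 3 to compound 4 (0.75 log units; beyond the scatter), the first readable size for any change in this side chain. The loss lies beyond the scatter, yet compound 4 still gives a real number, so a chain with an ether oxygen at this place is not by itself enough to reach the limit of the assay. The comparisons with the two earlier ethers give an at least 1.8-fold lower number from compound 2 to compound 4 (0.27 log units; that floor lies within the scatter), and, for methyl in place of hydrogen on the saturated chain carbon, an at least 1.8-fold lower number from compound 1 to compound 4 (0.27 log units; that floor lies within the scatter); both floors lie within the scatter, so neither shows a real gain, and their true sizes stay hidden: the limit of > 2000 nM in this assay, at which 2 of the 4 values shown sit.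

The swap from compound 3 to compound 4 replaces five carbons with three carbons and one oxygen, so these compounds cannot separate the effect of the oxygen from that of the changed chain. Also open, on these data alone, is how an amine in the chain in place of the ether oxygen, or a longer all-carbon chain on the same saturated chain carbon, would read in this assay.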